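Trading Amino for Dimethylamino: From Compound 3 to Compound 4

The source may hold more compounds than are shown below. What is called first, only, known or untested is meant among the compounds shown, and "the series" means these compounds.

Compound 1 `OC[C@H]1O[C@@H](n2cnc3c(NCc4ccccc4)nccc32)C[C@@H]1O` — in a functional assay on the whole organism (Pleural cavity) with Rattus norvegicus as the target (a higher number here means that more compound is needed for the effect, a lower number that less compound is needed), compound 1 gives > 9 mg/kg, a limit of the assay rather than a number.
Compound 2 `OCCNc1[nH]ccc2ncnc1-2` — in this assay compound 2 gives > 9 mg/kg, also a limit of the assay.
Compound 3 `Nc1nccc2c1ncn2[C@H]1C[C@H](O)[C@@H](CO)O1` — in this assay compound 3 gives 10 mg/kg.

Among the measured compounds shown here, compound 3 thus holds the only real number among the three; the other two values sit at the limit of > 9 mg/kg in this assay, at which 2 of the 3 values shown sit, and cannot be read as steps. For the measured compounds named here, the one step between structures that differ in a single place, a step that the limit leaves unreadable from compound 1 to compound 3, is for the same reason unreadable in size.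

Compound 4 `CN(C)c1nccc2c1ncn2[C@H]1C[C@H](O)[C@@H](CO)O1` has not yet been measured. It differs from compound 3 as follows: dimethylamino in place of amino on an aromatic carbon.

Going by the values given here, no measured step touches this kind of change, and the single readable value gives no direction to lean on. The expectation is therefore a change no larger than the scatter, with a fair chance that compound 4 ends at the limit. For compound 4 in this assay the estimate is 12 mg/kg, spanning 6 mg/kg to 25 mg/kg. This means the expected step of a 1.2-fold higher number from compound 3 to compound 4 (0.08 log units; within the scatter).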

Compound 4, dose for half-maximal effect: > 9 mg/kg
Compound 4: only a limit was reported (the forecaster's own chance of this, stated with the estimate: 40%); the middle value is on the limit's open side.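

In this assay compound 4 gives > 9 mg/kg as a limit of the assay, not a number, so its steps from compound 1 and compound 3 cannot be read: the limit of > 9 mg/kg in this assay, at which 3 of the 4 values shown sit.

The compounds shown leave open how much dimethylamino in place of amino on an aromatic carbon changes the dose needed.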